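Benzyl chloro placement and antiproliferative activity: working notes

This account rests on a few compounds, and the source may have more. Where it says the series, first, only, none or still open, it means among the compounds named here.

Compound 1 `NC(=O)c1c(NC(=O)c2ccccc2Cl)sc2c1CCN(Cc1ccccc1)C2`: 12000 nM
Compound 2 `Cc1ccccc1CN1CCc2c(sc(NC(=O)c3ccccc3Cl)c2C(N)=O)C1`: > 50000 nM (a limit of the assay, not a number)
Compound 3 `NC(=O)c1c(NC(=O)c2ccccc2Cl)sc2c1CCN(Cc1ccccc1Cl)C2`: 2900 nM

All three values come from a functional assay on HL-60 cells (Homo sapiens) for antiproliferative activity, with a stated time of 24 h; a lower number here means a stronger inhibitor, a higher number a weaker inhibitor. Compound 3 gives the lowest number at 2900 nM. Nearest to it is compound 1 at 12000 nM.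

The next compound is compound 4 `NC(=O)c1c(NC(=O)c2ccccc2Cl)sc2c1CCN(Cc1ccc(Cl)cc1)C2`, which has 4-chlorophenyl in place of 2-chlorophenyl on a saturated chain carbon bound to an amine nitrogen in a ring, or 2-chlorobenzyl changed to 4-chlorobenzyl: 4-chlorophenyl in place of 2-chlorophenyl on a saturated chain carbon bound to an amine nitrogen in a ring.

Among the compounds with values here, three measured steps bear on this change. For chloro in place of hydrogen on an aromatic carbon, the step is a 4.1-fold lower number from compound 1 to compound 3 (0.62 log units; beyond the scatter), which is modest. For methyl in place of hydrogen, it is an at least 4.1-fold higher number from compound 1 to compound 2 (0.61 log units; beyond the scatter). For chloro in place of methyl, it is an at least 17-fold lower number from compound 2 to compound 3 (1.23 log units; beyond the scatter), which is large. All of these concern substitution on the benzyl ring, but none shows 4-chlorophenyl directly.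

Within the data shown here, compound 4 keeps a chloro group, yet a 4.1-fold lower number from compound 1 to compound 3 (0.62 log units; beyond the scatter) was seen only with 2-chlorophenyl, so a modest move towards a higher number is expected in this assay. The expected step is a 2.1-fold higher number from compound 3 to compound 4 (0.32 log units; beyond the scatter). Compound 4 is estimated at 6000 nM, with an expected range of 1500 nM to 25000 nM.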

Compound 4, half-maximal inhibitory concentration: 22500 nM
Compound 4: the middle estimate sits 3.8-fold (0.57 log units) below what was measured; low and high end bracket the measured number.
By their numbers in this assay, from the lowest: compound 3; then compounds 1 and 4 (each within the scatter of the next). At a limit, above all of these: compound 2.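

In this assay, the place of the chloro group on the benzyl ring now proves to matter: the step of a 7.8-fold higher number from compound 3 to compound 4 (0.89 log units; beyond the scatter) joins two compounds with the same atoms, so the lower number seen with 2-chlorophenyl does not follow from the presence of chloro alone. With 4-chlorophenyl, chloro in place of hydrogen on an aromatic carbon gives a 1.9-fold higher number from compound 1 to compound 4 (0.27 log units; within the scatter), which leaves compound 4 and compound 1 not separable, whereas the same exchange giving compound 3 produced a step beyond the scatter. The step of an at least 2.2-fold lower number from compound 2 to compound 4 (0.34 log units; beyond the scatter) is read against a limit of the assay, not a number, and so gives only a minimum size: the limit of > 50000 nM in this assay, at which 1 of the 4 values shown sits.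

Among the compounds shown, the lower number with a group at this place is seen only with 2-chlorophenyl, and compound 2, with 2-methylphenyl, goes against any reading that a group there lowers the number in general. From the compounds shown here alone, how fluoro, methoxy or an amine on the same ring would stand in this assay remains open, as does whether the difference between 2-chlorobenzyl and 4-chlorobenzyl carries over to those groups.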